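Caffeic Amide Piperazines: Swapping the Aryl Halogen Pattern

The compounds below may be only part of what the source reports. "The series", "measured", "known", "first", "only" and "open" are said of these compounds alone.

The three measured compounds share one core, a caffeic acid amide joined to a piperazine that carries an aryl group on its far nitrogen. Compound 1 `O=C(/C=C/c1ccc(O)c(O)c1)N1CCN(c2ccccc2F)CC1` carries a 2-fluorophenyl there, and in a functional assay on B16-F10 cells (Mus musculus) for antiproliferative activity, read by MTT assay, with a stated time of 48 h (a lower number here means a stronger inhibitor, a higher number a weaker inhibitor), compound 1 gives 2.43 ug/mL. Compound 2 `O=C(/C=C/c1ccc(O)c(O)c1)N1CCN(c2ccc(F)cc2)CC1` carries a 4-fluorophenyl and in this assay compound 2 gives 1.68 ug/mL, while compound 3 `Cc1ccc(N2CCN(C(=O)/C=C/c3ccc(O)c(O)c3)CC2)c(C)c1` carries a 2,4-dimethylphenyl and compound 3 gives 1.43 ug/mL. Compound 1 thus stands highest of the three numbers, yet the step of a 1.4-fold lower number from compound 1 to compound 2 (0.16 log units; within the scatter) and the step of a 1.7-fold lower number from compound 1 to compound 3 (0.23 log units; within the scatter) both stay within the scatter, and so does a 1.2-fold lower number from compound 2 to compound 3 (0.07 log units; within the scatter).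

Compound 4 `O=C(/C=C/c1ccc(O)c(O)c1)N1CCN(c2ccc(Cl)c(Cl)c2)CC1` is the next member: 3,4-dichlorophenyl in place of 2-fluorophenyl on an amine nitrogen in a ring. The two steps that start from compound 1 bear on this change, and both are small, so the expected step in this assay is estimated as a 1.4-fold lower number from compound 1 to compound 4 (0.16 log units; within the scatter). Compound 4 is therefore estimated at 1.7 ug/mL, between 0.9 ug/mL and 3.3 ug/mL.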

Compound 4, half-maximal inhibitory concentration: 1.66 ug/mL
For compound 4 the middle estimate is 1.0-fold (0.01 log units) above the measured one, and the stated range covers the measured number.
By their numbers in this assay, from the lowest: compounds 3, 4, 2 and 1 (each within the scatter of the next).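

For the compounds shown here, with 3,4-dichlorophenyl, chlorine enters this series for the first time, and in this assay the number still does not move beyond the scatter from any earlier member: the steps are small on all sides (a 1.5-fold lower number from compound 1 to compound 4 (0.17 log units; within the scatter)), (a 1.0-fold lower number from compound 2 to compound 4 (0.01 log units; within the scatter)) and (a 1.2-fold higher number from compound 3 to compound 4 (0.06 log units; within the scatter)). On an amine nitrogen in a ring, then, two chlorine atoms give a result that cannot be told apart from those with one fluorine or two methyl groups, so none of the four aryl groups stands out at this position. No measurement shown here accounts for this lack of separation.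

The compounds shown leave open whether a methoxy group, an amine or a carboxylic acid on the phenyl ring would give a step beyond the scatter. They also leave open what a change elsewhere in the shared core would do, since all four keep it the same.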